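This account rests on a few compounds, and the source may have more. Where it says the series, first, only, none or still open, it means among the compounds named here.

Compound 1 `CC(C)c1cccc(C(C)C)c1NC(=O)CC(=O)O` carries a hydrogen on an oxygen next to a carbonyl group. In an assay on microsomes from intestine for inhibition of acyl-CoA:cholesterol acyltransferase (Oryctolagus cuniculus) (on this read-out higher numbers stand for weaker inhibition and lower numbers for stronger inhibition), compound 1 gives > 5000 nM, which is a limit of the assay rather than a number. Compound 2 `CC(C)c1cccc(C(C)C)c1OC(=O)CC(=O)Nc1ccccc1` returns > 5000 nM in this assay, again only a limit. Compound 3 `CC(C)c1cccc(C(C)C)c1NC(=O)CC(=O)OC(c1ccccc1)c1ccccn1` likewise gives > 5000 nM, once more a limit. Compound 1 therefore stands nowhere distinct among the values shown: the limit of > 5000 nM in this assay, at which 3 of the 3 values shown sit, and no measured step separates any two of these compounds.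

Compound 4 `CCCCCCCCOC(=O)CC(=O)Nc1c(C(C)C)cccc1C(C)C` has not yet been measured. It differs from compound 1 by octyl in place of hydrogen on an oxygen next to a carbonyl group. Among the measured compounds shown here, with all three known values sitting at a limit, no measured step shows how a change on this oxygen affects inhibition. The expectation is nevertheless that compound 4 reaches a measurable value, so the step of an at least 2.5-fold lower number from compound 1 to compound 4 (0.39 log units; beyond the scatter) is expected to run toward stronger inhibition. Compound 4 is accordingly estimated at 2000 nM, within a range from 300 nM to 10000 nM, with a fair chance that this assay again reports only a limit.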

Compound 4, half-maximal inhibitory concentration: 260 nM
The estimate for compound 4 lay 7.7-fold (0.89 log units) above the measured number; the measured number lies below the stated range.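

Octyl in place of hydrogen on an oxygen next to a carbonyl group gives an at least 19-fold lower number from compound 1 to compound 4 (1.28 log units; beyond the scatter) in this assay and so shows that a change at this place can move the read-out. Compound 4 alone yields a real number, so the size of this step is only a minimum: the limit of > 5000 nM in this assay, at which 3 of the 4 values shown sit. Not every group on this oxygen does the same, since compound 3 carries another group there and gives > 5000 nM, again only a limit.

The compounds shown hold a single chain, so it stays open whether a shorter chain such as butyl or a longer one such as dodecyl would do better or worse than octyl. On these data alone, it also stays open whether an amine or a carboxylic acid at the end of the octyl chain would be tolerated.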